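Compound 4 in the trifluoromethyl alkyne series

This account rests on a few compounds, and the source may have more. Where it says the series, first, only, none or still open, it means among the compounds named here.

Measured in an ADME assay on MT4 cells (Homo sapiens) for cytotoxicity, with a stated time of 5 days (on this read-out higher numbers stand for lower toxicity in this test and lower numbers for higher toxicity in this test), each entry a limit:
compound 1 (`CC(C)(C)C#Cc1cc(N(C(=O)[C@H]2CC[C@H](C)CC2)[C@H]2CC[C@H](Oc3ccc(=O)[nH]n3)CC2)c(C(=O)O)s1`), limit (> 20000 nM)
compound 2 (`C[C@H]1CC[C@H](C(=O)N(c2cc(C#CC3(C(F)(F)F)CC3)sc2C(=O)O)[C@H]2CC[C@H](Oc3ccc(=O)[nH]n3)CC2)CC1`), limit (> 20000 nM)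
compound 3 (`C[C@H]1CC[C@H](C(=O)N(c2cc(C#CC3(C(F)(F)F)CCC3)sc2C(=O)O)[C@H]2CC[C@H](Oc3ccc(=O)[nH]n3)CC2)CC1`), limit (> 20000 nM)

Compound 3 offers only a limit (> 20000 nM), not a number. The next change replaces 1-(trifluoromethyl)cyclobutyl with 1-methyl-1-(trifluoromethyl)ethyl on a triple-bonded carbon (1-methyl-1-(trifluoromethyl)ethyl in place of 1-(trifluoromethyl)cyclobutyl on a triple-bonded carbon), giving compound 4 (`CC(C)(C#Cc1cc(N(C(=O)[C@H]2CC[C@H](C)CC2)[C@H]2CC[C@H](Oc3ccc(=O)[nH]n3)CC2)c(C(=O)O)s1)C(F)(F)F`). Three measured steps change this same group: (a step that the two limits leave unreadable from compound 1 to compound 2), (a step that the two limits leave unreadable from compound 1 to compound 3) and (a step that the two limits leave unreadable from compound 2 to compound 3). None of them has a readable size, so they give no magnitude to carry over. Compound 1, compound 2 and compound 3 do share one limit (the limit of > 20000 nM in this assay, at which 3 of the 3 values shown sit), and on that basis no step beyond the scatter is expected in this assay, in either direction. The expected step is small (a step that the limit leaves unreadable from compound 3 to compound 4). For compound 4 the estimate is 22000 nM (expected range 12000 nM to 40000 nM), and the assay will most likely report a limit again.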

Compound 4, half-maximal cytotoxic concentration: > 20000 nM
Compound 4: only a limit was reported; the forecaster's own chance of this, stated with the estimate: 90%; the middle value lies beyond the limit too.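

In this assay, among these compounds, compound 4 again gives only a limit, > 20000 nM, so no step linking it to compound 1, compound 2 or compound 3 can be read: the limit of > 20000 nM in this assay, at which 4 of the 4 values shown sit. The compounds shown leave open how far any of these groups on the triple-bonded carbon separates in this assay.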